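A Second Fluorine on the Benzyl Ring of Compound 1

The compounds below may be only part of what the source reports. "The series", "measured", "known", "first", "only" and "open" are said of these compounds alone.

Compound 1 `O=C(O)c1ccccc1-c1ccc(CCc2ncc(Cc3cccc(F)c3)[nH]2)cc1` gives 7.9 nM in an in vitro functional assay on cells for agonist activity at Bombesin receptor subtype-3 (Mus musculus), read by luminescence and calcium flux (on this read-out higher numbers stand for an effect only at larger amounts of compound and lower numbers for an effect already at smaller amounts), the lower of the two numbers recorded, while compound 2 `CCCCc1cnc(C(CCCO)Cc2ccc(-c3ccccc3C(=O)O)cc2)[nH]1` gives 238 nM in this assay, a far larger number. No single change links these two, so their values show only that they differ widely. Compound 3 `O=C(O)c1ccccc1-c1ccc(CCc2ncc(Cc3cccc(F)c3F)[nH]2)cc1` is compound 1 with fluoro in place of hydrogen on an aromatic carbon, the new group sitting ortho to a fluoro group on the same ring. For the measured compounds named here, no measured pair shows a change of this kind. Compound 3 is expected to give about 8 nM, between 3 nM and 25 nM. The step of a 1.0-fold higher number from compound 1 to compound 3 (0.01 log units; within the scatter) is thus expected to stay within the usual scatter.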

Compound 3, half-maximal effective concentration: 8 nM
Compound 3: the middle estimate sits on the measured number at the digits printed; measured number inside the range.
By their numbers in this assay, from the lowest: compounds 1 and 3 (each within the scatter of the next); then compound 2.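

Going from 3-fluorobenzyl to 2,3-difluorobenzyl, this assay records a 1.0-fold higher number from compound 1 to compound 3 (0.01 log units; within the scatter) and so the two compounds read alike. This aromatic carbon, ortho to a fluoro group, therefore accepts fluoro in place of hydrogen on the core of compound 1 with no step beyond the usual scatter. Nothing measured on these compounds offers an explanation for this result.

As far as these compounds go, whether a methoxy group, a trifluoromethyl group or an amine at this same carbon would leave the number as it stands remains open. This single step also does not say how fluoro would behave on the other carbons of this ring.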